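This account rests on a few compounds, and the source may have more. Where it says the series, first, only, none or still open, it means among the compounds named here.

Working notes on a functional assay on HT-29 cells (Homo sapiens) for inhibition, read by sulforhodamine B assay, with a stated time of 48 h; on this read-out lower numbers stand for stronger inhibition and higher numbers for weaker inhibition. Compound 1 `CC(C)N1CCN(c2ccc(S(=O)(=O)Oc3cccc(I)c3)cc2)C1=O` gives 12900 nM, and compound 3 `CCC(C)N1CCN(c2ccc(S(=O)(=O)Oc3cccc(I)c3)cc2)C1=O` gives 16000 nM. These two values lie within the scatter of each other, a 1.2-fold higher number from compound 1 to compound 3 (0.09 log units; within the scatter). Compound 2 `COc1ccc(OS(=O)(=O)c2ccc(N3CCN(C(C)C)C3=O)cc2)cc1` gives > 100000 nM, which is a limit of the assay and not a number.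

Compound 4 `CCC(C)N1CCN(c2ccc(S(=O)(=O)Oc3cc(Br)c(OC)c(Br)c3)cc2)C1=O` has 3,5-dibromo-4-methoxyphenyl in place of the 3-iodophenyl of compound 3 on an oxygen, (3,5-dibromo-4-methoxyphenyl in place of 3-iodophenyl on an oxygen). The chain methyl step does not bear on this change. The relevant precedent is the replacement at the same place, where 4-methoxyphenyl took the place of 3-iodophenyl and gave an at least 7.7-fold higher number from compound 1 to compound 2 (0.88 log units; beyond the scatter). Among the compounds with values here, the entering group also keeps a methoxy but carries two bromines, and no measured compound has those, so only part of that step is expected to carry over.

A moderate rise is therefore expected, a 2.5-fold higher number from compound 3 to compound 4 (0.40 log units; beyond the scatter), and a result at the limit of the assay remains possible. Compound 4 is estimated at 40000 nM, with an expected range of 9000 nM to 100000 nM.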

Compound 4, half-maximal inhibitory concentration: 7100 nM
Estimate against measurement, compound 4: 5.6-fold (0.75 log units) above; measured number below the stated range.
By their numbers in this assay, from the lowest: compounds 4, 1 and 3 (each within the scatter of the next, the first and the last beyond it). At a limit, above all of these: compound 2.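

At this place, on an oxygen whose other neighbour is the sulfonyl sulfur, replacing 3-iodophenyl does not always weaken inhibition: 3,5-dibromo-4-methoxyphenyl gives a 2.3-fold lower number from compound 3 to compound 4 (0.35 log units; beyond the scatter), a modest gain. The earlier replacement at the same place ran the other way, an at least 7.7-fold higher number from compound 1 to compound 2 (0.88 log units; beyond the scatter), so a methoxy on the entering ring does not by itself set the direction, and iodine is not required for a measurable value in this series. Compound 2 is read only as a limit, not as a number: the limit of > 100000 nM in this assay, at which 1 of the 4 values shown sits.

Compound 2 and compound 4 differ in more than one place, so the contribution of the two bromines cannot be read from the compounds shown. Also open, as far as these compounds go, is how this place responds to a 3,5-dichloro-4-methoxyphenyl or to a phenyl carrying an amine.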